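A few compounds are considered here, and "the series" means these few. Any claim that something is new, unique, unknown or untested is made for them only; others in the source may bear on it.

Compound 1 `c1ccc(-c2ccc3[nH]ncc3c2)cc1` is the unsubstituted parent of this small series. In an assay on CHO-TREX cells for antagonist activity at transient receptor potential cation channel subfamily A member 1 (Homo sapiens), read by FLIPR and calcium flux, with a stated time of 10 min (a higher number here means a weaker inhibitor, a lower number a stronger inhibitor), compound 1 gives > 30000 nM, which is a limit of the assay rather than a number (the limit of > 30000 nM in this assay, at which 1 of the 3 values shown sits). Compound 2 `Fc1ccccc1-c1ccc2[nH]ncc2c1` gives 3950 nM in this assay, and compound 3 `CC(C)(C)c1ccccc1-c1ccc2[nH]ncc2c1` gives 3400 nM. The steps from the parent are an at least 7.5-fold lower number from compound 1 to compound 2 (0.88 log units; beyond the scatter) and an at least 8.8-fold lower number from compound 1 to compound 3 (0.94 log units; beyond the scatter), while between the two substituted compounds there is only a 1.2-fold lower number from compound 2 to compound 3 (0.07 log units; within the scatter).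

Compound 4 `N#Cc1ccccc1-c1ccc2[nH]ncc2c1` has not yet been measured in this assay. It differs from compound 1 by cyano in place of hydrogen on an aromatic carbon. The two measured steps bear directly on it, since fluoro and tert-butyl enter at the same place on the same ring, and both brought at least modest lower numbers, the fluoro step an at least 7.5-fold lower number from compound 1 to compound 2 (0.88 log units; beyond the scatter) and the tert-butyl step an at least 8.8-fold lower number from compound 1 to compound 3 (0.94 log units; beyond the scatter). Because a 1.2-fold lower number from compound 2 to compound 3 (0.07 log units; within the scatter) shows that two different groups at this place landed within the scatter of each other, a cyano group at the same place is expected to give a drop of similar size, from the limit of compound 1 down into the low-micromolar region.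

The step is therefore expected to be an at least 7.5-fold lower number from compound 1 to compound 4 (0.87 log units; beyond the scatter). Compound 4 is estimated at 4000 nM, with a likely range from 1500 nM to 12000 nM.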

Compound 4, half-maximal inhibitory concentration: 1290 nM
The estimate for compound 4 lay 3.1-fold (0.49 log units) above the measured number; measured number below the stated range.
By their numbers in this assay, from the lowest: compound 4; then compounds 3 and 2 (each within the scatter of the next). At a limit, above all of these: compound 1.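

Until now the two groups tried at this place, fluoro and tert-butyl, sat within the scatter of each other, so it could not be said that the choice of group mattered; in this assay cyano separates from both, with a 3.1-fold lower number from compound 2 to compound 4 (0.49 log units; beyond the scatter) and a 2.6-fold lower number from compound 3 to compound 4 (0.42 log units; beyond the scatter). The number at this place therefore depends on which group replaces the hydrogen and not only on the hydrogen being replaced, and among the three substituted compounds the cyano change gives the largest step from the parent, an at least 23-fold lower number from compound 1 to compound 4 (1.36 log units; beyond the scatter). The size of that step is only a lower bound, since compound 1 stands at a limit of the assay and not at a number: the limit of > 30000 nM in this assay, at which 1 of the 4 values shown sits.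

The compounds shown leave open whether other groups on this aromatic carbon, such as an amine, a carboxylic acid or a methoxy group, would give a number lower than that of compound 4 or would lose the gain. They also leave open whether cyano would give a similar step on any other carbon of the same ring, as every group here sits at the one place.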